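A few compounds are considered here, and "the series" means these few. Any claim that something is new, unique, unknown or untested is made for them only; others in the source may bear on it.

Cytotoxicity in an ADME assay on J774.1 cells (Mus musculus) for cytotoxicity, read by resazurin assay, with a stated time of 48 h (on this read-out lower numbers stand for stronger inhibition and higher numbers for weaker inhibition), has so far been measured for three compounds of the series. Compound 1 `CCCCn1cc(C(=O)NCc2ccccc2)c(=O)c2cc(F)c(-c3ccccc3)cc21` is recorded only as a limit of the assay, > 100000 nM. Compound 2 `CCCCn1cc(C(=O)O)c(=O)c2cc(F)c(N(C)Cc3ccccc3)cc21` gives 43200 nM in this assay, and compound 3 `CCCCn1cc(C(=O)NCc2ccccc2)c(=O)c2cc(F)c(N(C)Cc3ccccc3)cc21` gives 86000 nM. Of the two numbers, compound 2 has the lower one, with compound 3 nearest at a 2.0-fold higher number from compound 2 to compound 3 (0.30 log units; within the scatter), a step within the scatter; the third value shown is a limit. The other measured step, an at least 1.1-fold lower number from compound 1 to compound 3 (0.06 log units; that floor lies within the scatter), also stays within the scatter. Compound 4 `CCCCn1cc(C(=O)O)c(=O)c2cc(F)c(N(C)C)cc21` is not yet measured; it differs from compound 2 by hydrogen in place of phenyl on a saturated chain carbon bound to a nitrogen on an aromatic ring. Neither measured step touches this place, so no direct precedent exists; both measured steps elsewhere on the core were small, and all numbers shown are high. A step no larger than the scatter is therefore expected, a 1.3-fold higher number from compound 2 to compound 4 (0.10 log units; within the scatter). Compound 4 is estimated at 55000 nM in this assay, with a range from 22000 nM to 140000 nM, and a fair chance that only a limit is reported.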

Compound 4, half-maximal inhibitory concentration: > 100000 nM
Compound 4 gave a limit, no number; the forecaster's own chance of this, stated with the estimate: 35%; middle value at least 1.8-fold (0.25 log units) away from the limit.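

In this assay, within the data shown here, the change from benzyl(methyl)amino to dimethylamino gives an at least 2.3-fold higher number from compound 2 to compound 4 (0.36 log units; beyond the scatter), the only step printed as beyond the scatter. The phenyl on a saturated chain carbon bound to a nitrogen on an aromatic ring is therefore the one place shown where a change moves the number clearly, and its loss goes with weaker inhibition on this read-out. The value of compound 4 is a limit, so this step gives a floor and not a size: the limit of > 100000 nM in this assay, at which 2 of the 4 values shown sit.

From the compounds shown here alone, whether the phenyl ring itself counts, or only the length of the chain on that nitrogen, stays open; an ethyl or a cyclohexylmethyl group there would separate the two. Also open, going by these compounds, is whether the same change holds with the benzylamide in place of the carboxylic acid.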